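Sulfonamide aryl variation: the unsubstituted phenyl analogue

The compounds below may be only part of what the source reports. "The series", "measured", "known", "first", "only" and "open" are said of these compounds alone.

Compound 3 `Cc1cc(C)cc(NS(=O)(=O)c2ccc(N3CCNC3=O)cc2)c1` gives 100 nM in a functional assay on MCF7 cells (Homo sapiens) for antiproliferative activity, read by sulforhodamine B assay, with a stated time of 48 h (on this read-out higher numbers stand for weaker inhibition and lower numbers for stronger inhibition), level with compound 1 `O=C1NCCN1c1ccc(S(=O)(=O)Nc2cccc(Br)c2)cc1`, which gives 100 nM; together they are the lowest of the three numbers, while compound 2 `O=C1NCCN1c1ccc(S(=O)(=O)Nc2ccc(F)c(F)c2)cc1` gives 620 nM. The step of no change at the digits printed from compound 1 to compound 3 (within the scatter) shows that exchanging one aryl substitution pattern for another can leave the number unchanged, whereas a 6.2-fold higher number from compound 1 to compound 2 (0.79 log units; beyond the scatter) and a 6.2-fold lower number from compound 2 to compound 3 (0.79 log units; beyond the scatter) show that it can also shift it modestly. Compound 4 `O=C1NCCN1c1ccc(S(=O)(=O)Nc2ccccc2)cc1` differs from compound 3 by phenyl in place of 3,5-dimethylphenyl on a sulfonamide nitrogen. For the measured compounds named here, no measured step removes both substituents from the aryl ring, so only a loose expectation is possible: a modest rise in the number is expected, a 2.2-fold higher number from compound 3 to compound 4 (0.34 log units; beyond the scatter), since the two substituted analogues compound 1 and compound 3 sit lowest. Compound 4 is therefore estimated at 220 nM, within 70 nM to 700 nM.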

Compound 4, half-maximal inhibitory concentration: 470 nM
For compound 4 the middle estimate is 2.1-fold (0.33 log units) below the measured one; the measured number falls inside the stated range.
By their numbers in this assay, from the lowest: compounds 1 and 3 (each within the scatter of the next); then compounds 4 and 2 (each within the scatter of the next).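

Bare phenyl gives up the low numbers of both substituted partners in this assay: a 4.7-fold higher number from compound 3 to compound 4 (0.67 log units; beyond the scatter) and, for loss of the bromo alone, a 4.7-fold higher number from compound 1 to compound 4 (0.67 log units; beyond the scatter). Substitution on this ring does not by itself set the number, since compound 2 goes against that pattern: a 1.3-fold lower number from compound 2 to compound 4 (0.12 log units; within the scatter), so its 3,4-difluorophenyl group does not separate from phenyl. No measurement shown accounts for these steps. From the compounds shown here alone, whether a single methyl, a methoxy or an amine on this ring would match the bromo or the bare phenyl stays open.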